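Replacing a Carboxy Group with Phenyl on the Shared Core

This account rests on a few compounds, and the source may have more. Where it says the series, first, only, none or still open, it means among the compounds named here.

Measured so far:
compound 1, `COC(=O)c1ccc(CNn2sc3ccccc3c2=O)cc1`, 93.9 nM
compound 2, `O=C(O)c1ccc(CNn2sc3ccccc3c2=O)cc1`, 278 nM

Both compounds were tested in an assay on HeLa cells for inhibition of Monoglyceride lipase (Rattus norvegicus), read by LC-MS, with a stated time of 10 min; a higher number here means a weaker inhibitor, a lower number a stronger inhibitor. Going by the values given here, compound 1 gives 93.9 nM and compound 2 gives 278 nM, so compound 2 holds the higher of the two numbers, separated from its only neighbour by a 3.0-fold higher number from compound 1 to compound 2 (0.47 log units; beyond the scatter).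

Compound 3 `O=c1c2ccccc2sn1NCc1ccc(-c2ccccc2)cc1` has not been measured in this assay. It differs from compound 2 by phenyl in place of carboxy on an aromatic carbon. Among the compounds with values here, no measured step introduces a phenyl, so the change is untested. Within the data shown here, the one step known, a 3.0-fold higher number from compound 1 to compound 2 (0.47 log units; beyond the scatter), shows that the carboxy present in compound 2 goes with the higher number; removing it in compound 3 may bring the number back down, but the phenyl itself is a guess. The expected step is therefore modest, a 4.0-fold lower number from compound 2 to compound 3 (0.60 log units; beyond the scatter), with a wide range. Compound 3 is estimated at 70 nM, between 15 nM and 300 nM.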

Compound 3, half-maximal inhibitory concentration: 322 nM
Estimate against measurement, compound 3: 4.6-fold (0.66 log units) below; measured number outside the range, above it.
By their numbers in this assay, from the lowest: compound 1; then compounds 2 and 3 (each within the scatter of the next).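

In this assay phenyl in place of carboxy on this aromatic carbon gives a 1.2-fold higher number from compound 2 to compound 3 (0.06 log units; within the scatter) and so leaves the two compounds indistinguishable, even though the change adds a six-membered aromatic ring and removes a hydrogen-bond donor and acceptor. Taking away the carboxy therefore does not by itself lower the number when phenyl is what enters. Phenyl in place of methoxycarbonyl gives a 3.4-fold higher number from compound 1 to compound 3 (0.54 log units; beyond the scatter) and so, among the three groups seen here, only methoxycarbonyl stands apart.

Still open, on these data alone, is whether that difference belongs to esters in general, which an ethyl ester or an amide at the same place could test. A small amine or a longer alkyl chain there could also show how far the number moves from this position.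

Nothing available here bears on the reason for these results.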